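This account rests on a few compounds, and the source may have more. Where it says the series, first, only, none or still open, it means among the compounds named here.

Measured so far:
compound 1 `Cc1ccc([C@@H](C)Oc2cc3onc(CCC(=O)O)c3cc2Cl)nc1` — 0.31 L/kg
compound 2 `CCOc1cc2oc(=O)n(CCC(=O)O)c2cc1Cl` — 0.36 L/kg

Within the data shown here, in an ADME assay on the whole organism (strain Han-Wistar) for pharmacokinetics, with Rattus norvegicus as the target, read by LC-MS, at a dose of 1 mg/kg by the intravenous route (on this read-out higher numbers stand for wider distribution into tissues and lower numbers for narrower distribution), compound 1 gives 0.31 L/kg, the smaller of the two numbers so far, though compound 2 at 0.36 L/kg sits within the scatter of it, so the pair shows no difference of note. Compound 3 `C[C@@H](Oc1cc2onc(CCC(=O)O)c2cc1Cl)c1ccccn1` is the next compound to be measured in this assay. It differs from compound 1 only in this: hydrogen in place of methyl on an aromatic carbon. Among the measured compounds shown here, no pair of measured compounds shows what such a change does here. With only a methyl lost, no step beyond the scatter is expected from compound 1; the expected step is a 1.0-fold lower number from compound 1 to compound 3 (0.01 log units; within the scatter). Compound 3 is therefore estimated at 0.3 L/kg, in the range 0.18 L/kg to 0.5 L/kg.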

Compound 3, volume of distribution at steady state in the Rattus norvegicus assay: 0.42 L/kg
Estimate against measurement, compound 3: 1.4-fold (0.15 log units) below; measured number inside the range.
By their numbers in the Rattus norvegicus assay, from the lowest: compounds 1, 2 and 3 (each within the scatter of the next).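

Among these compounds, replacing 5-methylpyridin-2-yl with pyridin-2-yl gives a 1.4-fold higher number from compound 1 to compound 3 (0.13 log units; within the scatter) in the Rattus norvegicus assay, the first reading for this position, so the methyl can be lost without a change beyond the scatter. In a physicochemical assay for solubility, with a stated time of 24 h (on this read-out lower numbers stand for lower solubility and higher numbers for higher solubility), compound 1 gives > 860 ug/mL, which is a limit and not a number. In the physicochemical assay compound 3 gives > 7440 ug/mL, also a limit, so the step for this change cannot be read.

From the compounds shown here alone, whether an amine or a methoxy group at this position would move volume of distribution at steady state beyond the scatter remains open. Solubility for this pair also remains unresolved.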